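The source may hold more compounds than are shown below. What is called first, only, known or untested is meant among the compounds shown, and "the series" means these compounds.

Measured so far in a functional assay on SW-620 cells (Homo sapiens) for antiproliferative activity, read by MTT assay, with a stated time of 24 h; a lower number here means a stronger inhibitor, a higher number a weaker inhibitor:
- compound 1 `COc1ccc(C(=O)/C=C/c2ccc([N+](=O)[O-])cc2)c2c1C=CC(C)(C)O2`: 3520 nM
- compound 2 `COc1ccc(/C=C/C(=O)c2ccc(OC)c3c2OC(C)(C)C=C3)cn1`: > 10000 nM (a limit)
- compound 3 `COc1ccc(C(=O)/C=C/c2cccc(Cl)c2)c2c1C=CC(C)(C)O2`: > 10000 nM (a limit)

Compound 3 has no number, only the limit > 10000 nM. It shares that position with compound 2: the limit of > 10000 nM in this assay, at which 2 of the 3 values shown sit. Only compound 1 gives a true number.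

The next compound is compound 4 `COc1ccc(C(=O)/C=C/c2ccccc2Cl)c2c1C=CC(C)(C)O2`, which carries 2-chlorophenyl in place of 3-chlorophenyl on a double-bonded chain carbon bound to a double-bonded chain carbon.

Two measured steps lead to the limit, an at least 2.8-fold higher number from compound 1 to compound 3 (0.45 log units; beyond the scatter) and an at least 2.8-fold higher number from compound 1 to compound 2 (0.45 log units; beyond the scatter). Both lie beyond the scatter, but both replace 4-nitrophenyl, and neither moves a chlorine. The remaining comparison, a step that the two limits leave unreadable from compound 2 to compound 3, gives no usable size. Among the measured compounds shown here, no measured step therefore matches this change directly, and the expectation rests mainly on compound 3, whose limit is > 10000 nM. No step beyond the scatter is expected in this assay, and another limit is the likeliest report. The expected change is a number no higher from compound 3 to compound 4 (the limit leaves the size open). For compound 4 the estimate is 10000 nM, with an expected range from 4000 nM to 25000 nM.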

Compound 4, half-maximal inhibitory concentration: > 10000 nM
Compound 4 gave a limit, no number; the forecaster's own chance of this, stated with the estimate: 60%; the middle value lies on the limit itself.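

In this assay, shifting the chlorine from 3-chlorophenyl to 2-chlorophenyl on a double-bonded chain carbon bound to a double-bonded chain carbon still yields no number, and compound 4 stands at a limit, > 10000 nM. The replacement of 4-nitrophenyl now reads an at least 2.8-fold higher number from compound 1 to compound 4 (0.45 log units; beyond the scatter), so a third group at this place falls short of the 4-nitrophenyl result, and neither chlorine placement shown recovers it. The steps among compound 2, compound 3 and compound 4 cannot be read, and this place now gives little resolution in this series: the limit of > 10000 nM in this assay, at which 3 of the 4 values shown sit.

Going by these compounds, how far compound 2, compound 3 and compound 4 lie from one another remains open, as does whether any group other than 4-nitrophenyl can give a true number at this place. The data do not separate the placement of the substituent on the phenyl ring from the nitro group itself. A 4-chlorophenyl or a 4-aminophenyl group would allow that comparison with compound 1.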